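The source may report more compounds than this note shows. Statements on the series, on what has been measured and on what is new or still open speak of the compounds shown alone.

Working notes on the shared core of compound 1 `CNc1nc(Cl)nc2c1ncn2[C@@H]1O[C@H](C(=O)N2CCOCC2)[C@@H](O)[C@H]1O`, a series of purine nucleoside amides. In an assay on CHO cells for displacement of a labelled ligand from adenosine receptor A3 (Homo sapiens) (on this read-out lower numbers stand for stronger inhibition and higher numbers for weaker inhibition), compound 1 gives 3890 nM. Among the measured compounds shown here, compound 2 `O=C([C@H]1O[C@@H](n2cnc3c(NCc4cccc(I)c4)nc(Cl)nc32)[C@H](O)[C@@H]1O)N1CCOCC1` carries a 3-iodophenyl on the saturated chain carbon bound to the ring nitrogen, and in this assay compound 2 gives 513 nM; the step of a 7.6-fold lower number from compound 1 to compound 2 (0.88 log units; beyond the scatter) is the only single-point change measured so far. Compound 3 `Cc1ccccc1CNc1nc(Cl)nc2c1ncn2[C@@H]1O[C@H](C(=O)NCC2CC2)[C@@H](O)[C@H]1O` gives 29.5 nM in this assay, the lowest number of the three, and both gaps, to compound 2 and to compound 1, lie beyond the scatter.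

Compound 4 `Cc1ccccc1CNc1nc(Cl)nc2c1ncn2[C@@H]1O[C@H](C(=O)N2CCOCC2)[C@@H](O)[C@H]1O` differs from compound 3 in one place: morpholin-4-yl in place of (cyclopropylmethyl)amino on a carbonyl carbon. For the measured compounds named here, no measured step bears on this change, since compound 1 and compound 2 both carry the morpholinyl amide and neither differs from compound 3 only there; compound 2 and compound 3 differ in two places, so their values show only that the morpholinyl-bearing compound 2 has the higher number. With nothing direct to lean on, a weakening step toward the range of compound 2 is expected, a 10-fold higher number from compound 3 to compound 4 (1.01 log units; beyond the scatter). For compound 4 the expected value in this assay is 300 nM, with a range from 60 nM to 1500 nM.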

Compound 4, inhibition constant: 7590 nM
Compound 4: the middle estimate sits 25-fold (1.40 log units) below what was measured; the measured number lies above the stated range.
By their numbers in this assay, from the lowest: compound 3; then compound 2; then compounds 1 and 4 (each within the scatter of the next).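

In this assay, the amide position now has a direct reading: with 2-methylphenyl held, morpholin-4-yl in place of (cyclopropylmethyl)amino on a carbonyl carbon gives a 260-fold higher number from compound 3 to compound 4 (2.41 log units; beyond the scatter) and is the largest single-point step in the series. With the morpholinyl amide held, 2-methylphenyl in place of 3-iodophenyl gives a 15-fold higher number from compound 2 to compound 4 (1.17 log units; beyond the scatter), while 2-methylphenyl in place of hydrogen gives a 2.0-fold higher number from compound 1 to compound 4 (0.29 log units; within the scatter) and so leaves those two compounds level within the scatter. Nothing available here accounts for the size of these steps.

On these data alone, it remains open whether the step at the carbonyl carbon is as large with 3-iodophenyl or hydrogen on the chain carbon. Also open, as far as these compounds go, is whether a simple ethylamino or dimethylamino group on that carbonyl carbon would stand nearer compound 3 or compound 4.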